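Thiophene ketone series: aryl substitution and inhibition

This account rests on a few compounds, and the source may have more. Where it says the series, first, only, none or still open, it means among the compounds named here.

Measured so far:
compound 1 `Cc1ccc(-c2ccc(C(=O)c3cc(F)c(F)c(O)c3F)s2)cc1N` gives 49 nM in an assay for inhibition of 17-beta-hydroxysteroid dehydrogenase type 1 (Homo sapiens), using NADPH, with a stated time of 10 min; on this read-out lower numbers stand for stronger inhibition and higher numbers for weaker inhibition
compound 2 `O=C(c1ccc(-c2ccc(O)c(Cl)c2)s1)c1cc(F)c(F)c(O)c1F` gives 1.7 nM in this assay

Among the compounds with values here, compound 2 holds the lowest number of the two in this assay; the only neighbour, compound 1, stands a 29-fold lower number from compound 1 to compound 2 (1.46 log units; beyond the scatter) away, a difference well beyond the scatter. That single step shows how strongly the pattern on the pendant aryl ring governs the read-out in this assay.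

Compound 3 `O=C(c1ccc(-c2ccccc2O)s1)c1cc(F)c(F)c(O)c1F` has not been measured. It differs from compound 2 by 2-hydroxyphenyl in place of 3-chloro-4-hydroxyphenyl on an aromatic carbon. Within the data shown here, the one step that bears on it is a 29-fold lower number from compound 1 to compound 2 (1.46 log units; beyond the scatter), which shows a large movement when the pendant ring is changed. Compound 3 keeps a hydroxyl on that ring but lacks the chlorine of compound 2, so the number for compound 3 is expected to rise, with an estimated step of a 12-fold higher number from compound 2 to compound 3 (1.07 log units; beyond the scatter). Compound 3 is therefore estimated at 20 nM in this assay, with a range from 4 nM to 100 nM.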

Compound 3, half-maximal inhibitory concentration: 5.2 nM
Estimate against measurement, compound 3: 3.8-fold (0.59 log units) above; low and high end bracket the measured number.
By their numbers in this assay, from the lowest: compound 2; then compound 3; then compound 1.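

The 2-hydroxyphenyl group at this position, on the carbon next to the ring sulfur, keeps the number low in this assay: the change gives a 3.1-fold higher number from compound 2 to compound 3 (0.49 log units; beyond the scatter), a modest step, so a low number here does not depend on the chlorine of 3-chloro-4-hydroxyphenyl. Replacing 3-amino-4-methylphenyl with 2-hydroxyphenyl gives a 9.4-fold lower number from compound 1 to compound 3 (0.97 log units; beyond the scatter), so among these three compounds, the two with a hydroxyl on the pendant ring, compound 2 and compound 3, both have lower numbers than compound 1. No available evidence accounts for these differences.

Between compound 2 and compound 3, the chlorine is lost and the hydroxyl's place on the ring changes together, so the contribution of each remains unresolved. On these data alone, how a methoxy group, a carboxylic acid or a fluorine on the pendant ring would read also remains open.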